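Furan for Thiophene on a Nucleoside Core

The compounds below may be only part of what the source reports. "The series", "measured", "known", "first", "only" and "open" are said of these compounds alone.

Compound 1 `CN(C)c1ncnc2c1c(-c1ccoc1)cn2[C@@H]1O[C@H](CO)[C@@H](O)[C@H]1O` gives 9060 nM in a functional assay on HeLa S3 cells (Homo sapiens) for antiproliferative activity, read by XTT assay, with a stated time of 72 h; a lower number here means a stronger inhibitor, a higher number a weaker inhibitor. Compound 2 `CN(C)c1ncnc2c1c(-c1cccs1)cn2[C@@H]1O[C@H](CO)[C@@H](O)[C@H]1O` reaches only the limit > 20000 nM in this assay. Compound 3 `Nc1nc(N)c2c(-c3cccs3)cn([C@@H]3O[C@H](CO)[C@@H](O)[C@H]3O)c2n1` likewise reaches only the limit > 20000 nM in this assay.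

Compound 2 and compound 1 differ by one change, (furan-3-yl in place of thiophen-2-yl on an aromatic carbon), which brought an at least 2.2-fold lower number from compound 2 to compound 1 (0.34 log units; beyond the scatter); the size is known only as a minimum because of the limit of > 20000 nM in this assay, at which 2 of the 3 values shown sit. How the cores of compound 2 and compound 3 differ is not broken down here.

Compound 4 `Nc1nc(N)c2c(-c3ccoc3)cn([C@@H]3O[C@H](CO)[C@@H](O)[C@H]3O)c2n1` carries the same change, (furan-3-yl in place of thiophen-2-yl on an aromatic carbon). For compound 4 the expected step is an at least 1.6-fold lower number from compound 3 to compound 4 (0.22 log units; that floor lies within the scatter), judged against the measured at least 2.2-fold lower number from compound 2 to compound 1 (0.34 log units; beyond the scatter) and the limit of compound 3. Compound 4 is estimated at 12000 nM, within 3000 nM to 40000 nM.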

Compound 4, half-maximal inhibitory concentration: > 20000 nM
Compound 4 was reported as a limit (the forecaster's own chance of this, stated with the estimate: 45%); middle value at least 1.6-fold (0.22 log units) away from the limit.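

In this assay, for the compounds shown here, compound 3 and compound 4 both stand at a limit, and no step between them can be read because of it: the limit of > 20000 nM in this assay, at which 3 of the 4 values shown sit.

From the compounds shown here alone, whether furan-3-yl in place of thiophen-2-yl lowers the number on the core of compound 3, as it does on the core of compound 1, stays open.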